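The compounds below may be only part of what the source reports. "The series", "measured", "known", "first", "only" and "open" are said of these compounds alone.

Measured in a functional assay on Ramos cells (Homo sapiens) for antiproliferative activity, read by CCK-8 assay, with a stated time of 72 h, tested at 40 uM; a lower number here means less inhibition, a higher number more inhibition at the concentration tested (going by the name of the read-out):
compound 1 `CN1CCN(c2ccc(Nc3nc(-c4cccc(NC(=O)c5ccccc5)c4)sc3C(=O)O)cc2)CC1` gives 26.3%
compound 2 `CN1CCN(c2ccc(Nc3nc(-c4cccc(NC(=O)c5ccc(C(F)(F)F)cc5)c4)sc3C(N)=O)cc2)CC1` gives 97.8%
compound 3 `CN1CCN(c2ccc(Nc3nc(-c4cccc(NC(=O)c5ccc(C(C)(C)C)cc5)c4)sc3C(N)=O)cc2)CC1` gives 80.1%

Compound 3 stands second highest of the three numbers; the nearest is compound 2, higher beyond the scatter, and the furthest is compound 1, far lower. Going by the values given here, the only counted step, a number 17.7 percentage points lower from compound 2 to compound 3 (beyond the scatter), exchanges one group on the aromatic carbon for another; no measured step removes that group altogether. Compound 4 `CN1CCN(c2ccc(Nc3nc(-c4cccc(NC(=O)c5ccccc5)c4)sc3C(N)=O)cc2)CC1` differs from compound 3 by hydrogen in place of tert-butyl on an aromatic carbon. Compound 1 carries the same benzoyl as compound 4 and a much lower number, but the pair is not a counted step, so it gives no direct guide. Among the compounds with values here, with both substituted amides high and no step bearing directly on the removal, a modest downward step is expected in this assay, a number 12.1 percentage points lower from compound 3 to compound 4 (beyond the scatter), with a wide range. Compound 4 is therefore estimated at 68%, between 42% and 92%.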

Compound 4, a percentage reported as inhibition, at one concentration (the size of the read-out at that concentration, not a potency): 98.1%
Beside the measured number, compound 4's estimate is 30.1 percentage points below it; the measured number lies above the stated range.
By their numbers in this assay, from the lowest: compound 1; then compound 3; then compounds 2 and 4 (each within the scatter of the next).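

In this assay, the step of a number 18 percentage points higher from compound 3 to compound 4 (beyond the scatter) shows that the para substituent on the benzoyl is not needed for a high number, as the unsubstituted benzoyl exceeds the tert-butyl compound. The step of a number 0.3 percentage points higher from compound 2 to compound 4 (within the scatter) shows that trifluoromethyl and hydrogen cannot be told apart at this position, leaving tert-butyl the only lower one. With the benzoyl held constant, the step of a number 71.8 percentage points higher from compound 1 to compound 4 (beyond the scatter) sets the primary amide far above the carboxylic acid.

As far as these compounds go, a methoxy group or an amine at this position remains open, as does a nitrile or methyl ester in place of the primary amide. No evidence bears on the cause of these differences.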